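Swapping the Piperazine Cap for a Chlorobenzyl Group

This account rests on a few compounds, and the source may have more. Where it says the series, first, only, none or still open, it means among the compounds named here.

Compound 1 `COC(=O)CC/C(C)=C/Cc1c(OC)c(C)c2c(c1OCC#CCN1CCN(C(c3ccccc3)c3ccccc3)CC1)C(=O)OC2` — > 50000 nM
Compound 2 `COC(=O)CC/C(C)=C/Cc1c(OC)c(C)c2c(c1OCC#CCN1CCN(C(=O)C3COc4ccccc4O3)CC1)C(=O)OC2` — > 50000 nM

Of the compounds shown here, two built on one shared core have been tested in a functional assay on MDA-MB-231 cells (Homo sapiens) for inhibition, read by sulforhodamine B assay; a higher number here means a weaker inhibitor, a lower number a stronger inhibitor. Compound 1 gives > 50000 nM, which is a limit of the assay rather than a number. Compound 2 gives > 50000 nM, again a limit. Compound 2 thus stands at the limit of > 50000 nM in this assay, at which 2 of the 2 values shown sit, so there is no measurable inhibition to place it against anything else. Compound 3 `COC(=O)CC/C(C)=C/Cc1c(OC)c(C)c2c(c1OCC#CCN1CCN(Cc3ccc(Cl)cc3)CC1)C(=O)OC2` differs from compound 2 on the amine nitrogen in the ring: 4-chlorobenzyl in place of (2,3-dihydro-1,4-benzodioxin-2-yl)carbonyl on an amine nitrogen in a ring. For the measured compounds named here, no step between measured compounds is available here, so no measured guide exists for the size or direction of this change; both neighbours simply sit at the limit. Compound 3 is expected to give about 50000 nM, within a range of 20000 nM to 120000 nM. For compound 3 the estimated step is a number no higher from compound 2 to compound 3 (the limit leaves the size open), none beyond the scatter, and most likely another limit.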

Compound 3, half-maximal inhibitory concentration: > 50000 nM
Compound 3: no number, only a limit; the forecaster's own chance of this, stated with the estimate: 75%; the middle value sits exactly at the limit.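

For the compounds shown here, compound 3 gives only a limit, as compound 2 does, so no step between compound 2 and compound 3 can be read: the limit of > 50000 nM in this assay, at which 3 of the 3 values shown sit. The compounds shown leave open which group on the amine nitrogen in the ring, if any, would give measurable inhibition on the shared core.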